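The compounds below may be only part of what the source reports. "The series", "measured", "known", "first", "only" and "open" are said of these compounds alone.

Compound 1 `N=C(N)Nc1cccc(C(=O)NNC(=O)NC(CC(=O)O)C(N)=O)c1` is one of two compounds with a number in a physicochemical assay for lipophilicity; on this read-out lower numbers stand for lower lipophilicity and higher numbers for higher lipophilicity. In this assay compound 1 gives -2.42, the lowest of the two numbers. The other measured compound is compound 2 `CC(=N)Nc1cccc(C(=O)NNC(=O)CC(CC(=O)O)c2ccc(Cl)cc2)c1`, which in this assay gives 2, a number that lies well beyond the scatter above that of compound 1. Among the measured compounds shown here, no single-point step connects compound 1 and compound 2, so only their two values can be set side by side.

Compound 3 `N=C(N)Nc1cccc(C(=O)NNC(=O)NC(CC(=O)O)c2ccc(OC(F)(F)F)cc2)c1` has not yet been measured. It differs from compound 1 in one place: 4-(trifluoromethoxy)phenyl in place of carbamoyl on a saturated chain carbon bound to an amide-type nitrogen and a saturated chain carbon. For the measured compounds named here, no measured step of this kind is available here. The step from compound 1 to compound 3 is expected to be a large rise, estimated at a number 3.42 log units higher from compound 1 to compound 3 (beyond the scatter), far beyond the scatter. On that basis compound 3 is expected to give about 1 in this assay, within a range from -0.2 to 2.2.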

Compound 3, partition coefficient: 2.23
Compound 3: the middle estimate sits 1.23 log units below what was measured; the measured number lies above the stated range.
By their numbers in this assay, from the lowest: compound 1; then compounds 2 and 3 (each within the scatter of the next).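

Among the compounds shown here, at the saturated chain carbon bound to an amide-type nitrogen and a saturated chain carbon, 4-(trifluoromethoxy)phenyl in place of carbamoyl gives a number 4.65 log units higher from compound 1 to compound 3 (beyond the scatter) in this assay, the first step here that can be read at a single place. Compounds 1 and 2 differ in more than one place, so their values could say nothing about this position alone, whereas this pair shows that a change at this carbon, with the rest of the core of compound 1 held fixed, is enough to produce a large step. The change swaps a group without a ring for one that carries a six-membered aromatic ring, but no measured information here accounts for the size of the step.

The compounds shown leave open how much of the step would remain with plain phenyl or 4-methoxyphenyl at this carbon, so the ring and the trifluoromethoxy group cannot be told apart. They also leave open whether the same exchange would give a step of similar size if the carboxylic acid on the chain were replaced by a methyl ester.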